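Butyl chain in place of hydroxypropyl on a telluro oxime

The source may report more compounds than this note shows. Statements on the series, on what has been measured and on what is new or still open speak of the compounds shown alone.

Measured compounds in a functional assay, read by spectrophotometry, with a stated time of 30 min; on this read-out higher numbers stand for weaker inhibition and lower numbers for stronger inhibition:
compound 1, `C/C(=N\O)c1ccc([Te]CCCO)cc1`: 13.1 ug/mL
compound 2, `C=CCNC(C)c1ccc([Te]CCCC)cc1`: > 100 ug/mL
compound 3, `CCCC[Te]c1ccc(C(C)NCc2ccccc2)cc1`: 11.4 ug/mL

In this assay compound 2 reaches only a limit, > 100 ug/mL, and no number. Compound 1 gives 13.1 ug/mL and compound 3 gives 11.4 ug/mL; these two numbers lie within the usual scatter of each other, so neither can be placed above the other. Going by the values given here, the single step between measured compounds that differ in one place is an at least 8.7-fold lower number from compound 2 to compound 3 (0.94 log units; beyond the scatter), a change on the amine side of the shared core, and the limit of > 100 ug/mL in this assay, at which 1 of the 3 values shown sits, is all that is known of its starting point.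

Compound 4, `CCCC[Te]c1ccc(/C(C)=N/O)cc1`, differs from compound 1 as follows: methyl in place of hydroxy on a saturated chain carbon, three bonds along the chain from a tellurium atom. Among the compounds with values here, no measured step touches this part of the molecule; the step of an at least 8.7-fold lower number from compound 2 to compound 3 (0.94 log units; beyond the scatter) alters a different position and therefore says nothing about exchanging hydroxy for methyl. Compound 2 and compound 3 both carry the butyl chain that enters here, but they differ from compound 4 elsewhere, so only their range of values, from a limit down to the number of compound 3, frames the outcome.

Within the data shown here, with no step bearing on the change, no shift beyond the scatter is expected. Compound 4 is therefore estimated at 13 ug/mL, with a range from 5 ug/mL to 35 ug/mL. That expectation corresponds to a 1.0-fold lower number from compound 1 to compound 4 (0.00 log units; within the scatter).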

Compound 4, half-maximal inhibitory concentration: 7.79 ug/mL
The estimate for compound 4 lay 1.7-fold (0.22 log units) above the measured number, within the range that was stated.
By their numbers in this assay, from the lowest: compounds 4, 3 and 1 (each within the scatter of the next). At a limit, above all of these: compound 2.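

Going by these compounds alone, this is the first measured step at the far end of the tellurium chain. With butyl in place of 3-hydroxypropyl on the shared core, this assay shows a 1.7-fold lower number from compound 1 to compound 4 (0.23 log units; within the scatter), so compound 1 and compound 4 cannot be placed in any order, and in this pair the oxime keeps a measured number with either chain. The hydroxy, with the hydrogen-bond donor and acceptor counted on it, can therefore give way to methyl at this place, on a saturated chain carbon, three bonds along the chain from a tellurium atom, without a shift beyond the scatter, a finding that holds for this one pair only. Nothing shown gives a cause for this result, and the single limit on hand belongs to a compound that differs elsewhere.

The compounds shown leave open whether an amine or a carboxylic acid at the end of this chain, or a chain longer than butyl, would stay within the scatter of compound 1. They also leave open whether 3-hydroxypropyl in place of butyl would read the same on the amine side of compound 3.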